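Bromo in place of cyclobutyl on a quaternary ammonium butanoate

The source may hold more compounds than are shown below. What is called first, only, known or untested is meant among the compounds shown, and "the series" means these compounds.

Two compounds share a dimethylammonium butanoate zwitterion and differ in the group on the nitrogen. Compound 1 `C[N+](C)(CCCC(=O)[O-])C1CCCC1` carries a cyclopentyl group; in an assay for inhibition of gamma-butyrobetaine dioxygenase (Homo sapiens), read by HPLC, with stated times of 15 min and 30 min (on this read-out higher numbers stand for weaker inhibition and lower numbers for stronger inhibition), compound 1 gives > 1000000 nM, which is a limit of the assay and not a number. Compound 2 `C[N+](C)(CCCC(=O)[O-])CC1CCC1` carries a cyclobutylmethyl group; in this assay compound 2 gives > 1000000 nM, again a limit rather than a number. Compound 2 thus stands at the limit of > 1000000 nM in this assay, at which 2 of the 2 values shown sit, with no measured number to place it against. Compound 3 `C[N+](C)(CBr)CCCC(=O)[O-]` is not yet measured and differs from compound 2 by bromo in place of cyclobutyl on a saturated chain carbon bound to an amine nitrogen. Among the compounds with values here, with both known values at the limit, no measured step is available to scale this change, and the direction of the step from compound 2 to compound 3 cannot be read from the data. The estimated step is an at least 3.3-fold lower number from compound 2 to compound 3 (0.52 log units; beyond the scatter), a move to stronger inhibition that remains uncertain. Compound 3 is expected to give about 300000 nM in this assay, within a range of 30000 nM to 1000000 nM.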

Compound 3, half-maximal inhibitory concentration: > 1000000 nM
Compound 3 gave a limit, no number; the forecaster's own chance of this, stated with the estimate: 55%; middle value at least 3.3-fold (0.52 log units) away from the limit.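

Within the data shown here, compound 2 and compound 3 both stand at a limit, not a number, in this assay, so no step between them can be read. The compounds shown leave open whether any group on the shared core would give a measurable value: the limit of > 1000000 nM in this assay, at which 3 of the 3 values shown sit.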